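Swapping Trifluoromethyl for Ethyl in Two Related Series

This account rests on a few compounds, and the source may have more. Where it says the series, first, only, none or still open, it means among the compounds named here.

Measured so far in a functional assay on PC-3 cells (Homo sapiens) for inhibition, read by MTT assay, with a stated time of 72 h; a lower number here means a stronger inhibitor, a higher number a weaker inhibitor:
- compound 1 `O=C(CSc1nc(Nc2ccccc2)c2ccccc2n1)Nc1ccc(C(F)(F)F)cc1` gives 10400 nM
- compound 2 `CCc1ccc(NC(=O)CSc2nc(Nc3ccccc3)c3ccccc3n2)cc1` gives 17900 nM
- compound 3 `C=CC(=O)Nc1cccc(NC(=O)CSc2nc(Nc3ccc(C(F)(F)F)cc3)c3ccccc3n2)c1` gives 12500 nM

Compound 1 and compound 2 differ by one change, (ethyl in place of trifluoromethyl on an aromatic carbon), and this gave a 1.7-fold higher number from compound 1 to compound 2 (0.24 log units; within the scatter). Compound 4 `C=CC(=O)Nc1cccc(NC(=O)CSc2nc(Nc3ccc(CC)cc3)c3ccccc3n2)c1` is related to compound 3 by the same change, (ethyl in place of trifluoromethyl on an aromatic carbon), at the same place. The difference between the core of compound 1 and the core of compound 3 is not broken down here; their values in this assay lie within the scatter of each other.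

Compound 4 is expected to follow the earlier step, since that step, in compound 1 and compound 2, was itself within the scatter; the expected step is a 1.6-fold higher number from compound 3 to compound 4 (0.20 log units; within the scatter). Compound 4 is therefore estimated at 20000 nM, most likely between 8000 nM and 50000 nM.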

Compound 4, half-maximal inhibitory concentration: 24300 nM
Compound 4: the middle estimate sits 1.2-fold (0.08 log units) below what was measured; low and high end bracket the measured number.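

In this assay putting ethyl in place of trifluoromethyl gave a 1.9-fold higher number from compound 3 to compound 4 (0.29 log units; within the scatter) and so stayed small on this second core as well. Set beside the earlier step, the two results agree: the same change on two cores in this assay, a 1.7-fold higher number (0.24 log units; within the scatter) from compound 1 to compound 2 and a 1.9-fold higher number (0.29 log units; within the scatter) from compound 3 to compound 4, 1.1-fold (0.05 log units) apart, within the scatter of two such steps

Within this pair of cores, the change therefore carried across with a similar small size. Each step lies within the scatter, however, so neither one shows that the change has a real effect, and two cores cannot establish a rule for the whole series.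

The compounds shown leave open whether another group at this place, such as an amine, a carboxylic acid or a longer chain, would give a step beyond the scatter.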